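Working notes on the shared-core series, step to compound 4

This account rests on a few compounds, and the source may have more. Where it says the series, first, only, none or still open, it means among the compounds named here.

Measured compounds:
Compound 1 `Cc1cc(NC(C)C)nc(SCc2nc3ccccc3[nH]2)n1` in a functional assay on MCF7 cells (Homo sapiens) for cytotoxicity, read by MTT assay, with a stated time of 72 h (on this read-out higher numbers stand for weaker inhibition and lower numbers for stronger inhibition), gives > 100000 nM, a limit.
Compound 2 `Cc1cc(NNC(N)=S)nc(SCc2nc3ccccc3[nH]2)n1` in this assay gives > 100000 nM, a limit.
Compound 3 `Cc1cc(Nc2cccc(C(F)(F)F)c2)nc(SCc2nc3ccccc3[nH]2)n1` in this assay gives > 100000 nM, a limit.

Compound 2 stands at the limit, as do the other two values shown (the limit of > 100000 nM in this assay, at which 3 of the 3 values shown sit). Going by the values given here, the one measured step, a step that the two limits leave unreadable from compound 1 to compound 2, cannot be read because both ends are limits. Compound 4 `Cc1cc(Nc2ccc(F)cc2)nc(SCc2nc3ccccc3[nH]2)n1` differs from compound 2 by a group of 7 heavy atoms (6 carbon, 1 fluorine; one six-membered aromatic ring of carbon only) in place of a group of 4 heavy atoms (1 carbon, 2 nitrogen, 1 sulfur; no ring), on a nitrogen on an aromatic ring. Among the compounds with values here, no measured step bears directly on this change; compound 3, which also carries an aromatic ring on that nitrogen, sits at the limit, and compound 2 sits at the limit. No step beyond the scatter is therefore expected in this assay, and the expected step is a step that the limit leaves unreadable from compound 2 to compound 4. Compound 4 is estimated at 150000 nM (range 30000 nM to 600000 nM), most likely reported again as a limit.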

Compound 4, half-maximal inhibitory concentration: 42200 nM
Estimate against measurement, compound 4: 3.6-fold (0.55 log units) above, within the range that was stated.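

In this assay, going by these compounds alone, 4-fluorophenyl on a nitrogen on an aromatic ring brings the first readable value, with an at least 2.3-fold lower number from compound 2 to compound 4 (0.37 log units; beyond the scatter) and an at least 2.3-fold lower number from compound 1 to compound 4 (0.37 log units; beyond the scatter). An aromatic ring on that nitrogen is not enough on its own: compound 3 also carries one and gives > 100000 nM, a limit. The step between the two earlier compounds cannot be read, and limits still dominate the series: the limit of > 100000 nM in this assay, at which 3 of the 4 values shown sit.

Going by these compounds, it remains open what a plain phenyl, or a phenyl carrying a carboxylic acid or an amine in place of the fluorine, would give. On these data alone, the true size of both new steps also remains open.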